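Carbamate nitrogen variation in the shared core series

The source may hold more compounds than are shown below. What is called first, only, known or untested is meant among the compounds shown, and "the series" means these compounds.

Among the measured compounds shown here, compound 2 `CCC(CC)NC(=O)OCC1CN(C(=O)c2cc(OC)c(OC)c(OC)c2)CCN1C(=O)c1cc(OC)c(OC)c(OC)c1` bears a (pentan-3-yl)amino group on a carbonyl carbon; in a functional assay (Oryctolagus cuniculus) for inhibition of platelet-activating factor receptor (Cavia porcellus) (on this read-out lower numbers stand for stronger inhibition and higher numbers for weaker inhibition), compound 2 gives 130 nM, the lowest of the two numbers measured so far. For the measured compounds named here, compound 1 `CCCC(=O)OCC1CN(C(=O)c2cc(OC)c(OC)c(OC)c2)CCN1C(=O)c1cc(OC)c(OC)c(OC)c1`, with propyl on that carbonyl carbon, gives 420 nM in this assay , and the step of a 3.2-fold lower number from compound 1 to compound 2 (0.51 log units; beyond the scatter) is the only measured step in the set.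

Compound 3 `CCCCN(CCCC)C(=O)OCC1CN(C(=O)c2cc(OC)c(OC)c(OC)c2)CCN1C(=O)c1cc(OC)c(OC)c(OC)c1` differs from compound 2 by dibutylamino in place of (pentan-3-yl)amino on a carbonyl carbon, read one bond further out as (pentan-3-yl)carbamoyl to dibutylcarbamoyl. Going by the values given here, no measured step exchanges one amino group for another; the single step of a 3.2-fold lower number from compound 1 to compound 2 (0.51 log units; beyond the scatter) concerns a different change and bears on the present one only indirectly. The expectation for compound 3 in this assay is therefore a step of uncertain direction, most likely within or just beyond the scatter, a 1.7-fold higher number from compound 2 to compound 3 (0.23 log units; within the scatter). Compound 3 is estimated at 220 nM, in the range 70 nM to 700 nM.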

Compound 3, half-maximal inhibitory concentration: 1250 nM
Estimate against measurement, compound 3: 5.7-fold (0.75 log units) below; the measured number lies above the stated range.
By their numbers in this assay, from the lowest: compound 2; then compound 1; then compound 3.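

The amino group on this carbonyl carbon is not interchangeable: in this assay the exchange of (pentan-3-yl)amino for dibutylamino gives a 9.6-fold higher number from compound 2 to compound 3 (0.98 log units; beyond the scatter), a larger step than the change from propyl to (pentan-3-yl)amino had shown. Dibutylamino also gives a 3.0-fold higher number from compound 1 to compound 3 (0.47 log units; beyond the scatter), so an amino group at this place does not in itself go with the lower number; compound 2 fits such a reading, and compound 3 goes against it. No available evidence accounts for the rise in the number.

The exchange removes the hydrogen-bond donor and adds heavy atoms together, so the compounds shown leave open which of these differences tracks the step. Butylamino or dimethylamino on this carbonyl carbon would help separate them.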